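The source may hold more compounds than are shown below. What is called first, only, known or untested is meant among the compounds shown, and "the series" means these compounds.

Measured in a functional assay on PANC-1 cells (Homo sapiens) for cytotoxicity, read by WST assay, with a stated time of 24 h; a higher number here means a weaker inhibitor, a lower number a stronger inhibitor:
compound 1 `O=C(/C=C/CCCCCCc1ccccc1)N1CCCCCC1`: > 100000 nM
compound 2 `O=C(/C=C/CCCCCCc1ccccc1)Nc1ccccc1`: > 100000 nM
compound 3 `O=C(/C=C/CCCCCCc1ccccc1)NCc1ccccc1`: > 100000 nM

Each of these entries is a limit and not a number. Going by these compounds, compound 3 reads > 100000 nM, so its true standing is unknown.

Compound 4 `O=C(/C=C/CCCCCCc1ccccc1)N[C@H]1CC[C@H](O)CC1` keeps the core of compound 3 and changes one group: 4-hydroxycyclohexyl in place of benzyl on an amide-type nitrogen. Among the measured compounds shown here, the steps that bear on this change on the amide-type nitrogen are a step that the two limits leave unreadable from compound 2 to compound 3 and a step that the two limits leave unreadable from compound 1 to compound 3. Neither offers a size to carry over. No readable step is expected in this assay, because of the limit of > 100000 nM in this assay, at which 3 of the 3 values shown sit. The expected step is a number no higher from compound 3 to compound 4 (the limit leaves the size open). For compound 4 the estimated value is 100000 nM, within an expected range of 50000 nM to 200000 nM.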

Compound 4, half-maximal inhibitory concentration: > 100000 nM
Compound 4 ended at the assay's limit; the forecaster's own chance of this, stated with the estimate: 85%; the middle value lies on the limit itself.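

No step can be read from compound 1, compound 2 or compound 3 to compound 4 in this assay, because every value is a limit: the limit of > 100000 nM in this assay, at which 4 of the 4 values shown sit. Going by these compounds, the true values of all four compounds, and whether changing the group on the amide-type nitrogen alters them, remain open.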